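The source may hold more compounds than are shown below. What is called first, only, known or untested is meant among the compounds shown, and "the series" means these compounds.

Compound 1 `CNC(=O)c1cc(C(=O)NC2CC2)cn(Cc2cccc3[nH]ccc23)c1=O` was measured in an ADME assay on the whole organism (Rattus norvegicus, strain Wistar Han) for pharmacokinetics, read by LC-MS, with a stated time of 7 h, at a dose of 1 mg/kg by the intravenous route (on this read-out lower numbers stand for narrower distribution and higher numbers for wider distribution into tissues), and gives 1.3 L/kg. Compound 2 `CCNC(=O)c1cc(C(=O)NC)c(=O)n(Cc2ccccc2)c1` gives 0.8 L/kg in this assay, and the two numbers lie within the usual scatter of each other, so neither stands apart from the other. Compound 3 `CNC(=O)c1cc(C(=O)NC2CC2)cn(Cc2cccc3c2CCN3)c1=O` has not yet been measured in this assay. It differs from compound 1 by 2,3-dihydro-1H-indol-4-yl in place of 1H-indol-4-yl on a saturated chain carbon bound to an aromatic nitrogen. Among the measured compounds shown here, no measured pair shows this change. The step of a 1.2-fold higher number from compound 1 to compound 3 (0.06 log units; within the scatter) is expected to be small and, if anything, upward, not beyond the scatter. Compound 3 is therefore estimated at 1.5 L/kg in this assay, within a range from 0.8 L/kg to 2.8 L/kg.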

Compound 3, volume of distribution at steady state: 0.9 L/kg
The estimate for compound 3 lay 1.7-fold (0.22 log units) above the measured number; the range from low to high includes it.
By their numbers in this assay, from the lowest: compounds 2, 3 and 1 (each within the scatter of the next).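

In this assay, the step with 2,3-dihydro-1H-indol-4-yl in place of 1H-indol-4-yl on a saturated chain carbon bound to an aromatic nitrogen is a 1.4-fold lower number from compound 1 to compound 3 (0.16 log units; within the scatter). This position therefore tolerates the loss of aromaticity in the five-membered ring without a change in volume of distribution that can be told from the scatter. No evidence at hand bears on this result.

Going by these compounds, whether an amine or a carboxylic acid in that place would take the number beyond the scatter remains open.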